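The source may report more compounds than this note shows. Statements on the series, on what has been measured and on what is new or still open speak of the compounds shown alone.

Within the data shown here, only two compounds in this set have a measured number in a physicochemical assay for lipophilicity, using potentiometric titration, at pH 7.4; on this read-out higher numbers stand for higher lipophilicity and lower numbers for lower lipophilicity. Compound 1 `CNC(=O)C(Cc1ccccc1Cl)CN1CCC2(CC1)OCCc1cc(Cl)sc12` gives 3.77, and compound 2 `CNC(=O)[C@@H](Cc1ccccc1F)CN1CCC2(CC1)OCCc1cc(F)sc12` gives 3.5. These two numbers lie within the usual scatter of repeated measurements, so on this read-out compound 1 and compound 2 cannot be told apart.

Compound 3 `NC(=O)C(Cc1ccccc1Cl)CN1CCC2(CC1)OCCc1cc(Cl)sc12` has not been measured yet. It differs from compound 1 in one place, with hydrogen in place of methyl on an amide-type nitrogen. Put another way, methylcarbamoyl becomes carbamoyl, and the rest of the structure stays the same.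

Among the measured compounds shown here, no pair of measured compounds shows this change on its own. The expectation can therefore rest only on the structural change itself and on the starting value of compound 1, 3.77. In this assay a modest downward step is expected, estimated as a number 0.37 log units lower from compound 1 to compound 3 (beyond the scatter). Compound 3 is therefore expected at 3.4 in this assay, with an estimated range of 3 to 3.8.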

Compound 3, distribution coefficient: 4.58
Compound 3: middle estimate off by 1.18 log units, on the low side, and the stated range ends below it.
By their numbers in this assay, from the lowest: compounds 2 and 1 (each within the scatter of the next); then compound 3.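

Among these compounds, on the amide-type nitrogen, replacing the methyl with hydrogen, so that methylcarbamoyl becomes carbamoyl, gives in this assay a clear change: a number 0.81 log units higher from compound 1 to compound 3 (beyond the scatter), and this is the first single-place step seen in the set. Compound 1 and compound 2 differ in more than one place, so they said nothing about this nitrogen alone; the new pair shows that the read-out responds to this one small edit, and that here the compound with one carbon fewer carries the higher number, so counting carbons would have pointed the wrong way for this pair. Nothing measured here explains why the number moves in this direction.

As far as these compounds go, this is a single pair, so it remains open whether an ethyl or a cyclopropyl group on the same nitrogen would give a number closer to compound 1 or move it further still. From the compounds shown here alone, it also remains open whether the same swap of methyl for hydrogen would give a similar step on the fluorine-bearing structure of compound 2.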